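Oxazole for nitrile: an untested change on a known scaffold

This account rests on a few compounds, and the source may have more. Where it says the series, first, only, none or still open, it means among the compounds named here.

Compound 1 `COc1ccccc1N1CCN(CCCNc2ccc(C(=O)N(C)C)cn2)CC1` in a functional assay on aorta for antagonist activity at Alpha-1D adrenergic receptor (Rattus norvegicus) (a higher number here means weaker binding, a lower number tighter binding), gives 31.6 nM.
Compound 2 `COc1ccccc1N1CCN(CCCOc2ccccc2C(=O)N(C)C)CC1` in this assay gives 31.6 nM.
Compound 3 `CN(C)C(=O)c1cccnc1NCCCN1CCN(c2ccccc2C#N)CC1` in this assay gives 10 nM.

Compound 3 has the lowest number of the three; compound 1 and compound 2 both sit well beyond the scatter above it. Compound 4 `CN(C)C(=O)c1cccnc1NCCCN1CCN(c2ccccc2-c2ncco2)CC1` is the untested analogue, differing only by 1,3-oxazol-2-yl in place of cyano on an aromatic carbon. For the measured compounds named here, no measured pair in this set carries that kind of change, so nothing here tells how a 1,3-oxazol-2-yl in place of cyano behaves. The author therefore expects, from compound 3 to compound 4, a step of a 2.0-fold higher number from compound 3 to compound 4 (0.30 log units; within the scatter) in the direction of a higher number, though likely within or only a little beyond the scatter. The estimate for compound 4 in this assay is 20 nM, within the range 5 nM to 80 nM.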

Compound 4, dissociation constant: 25.1 nM
The estimate for compound 4 lay 1.3-fold (0.10 log units) below the measured number; measured number inside the range.
By their numbers in this assay, from the lowest: compound 3; then compounds 4, 1 and 2 (each within the scatter of the next).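

Placing 1,3-oxazol-2-yl instead of cyano on this aromatic carbon, ortho to a large group, gives in this assay a 2.5-fold higher number from compound 3 to compound 4 (0.40 log units; beyond the scatter), a modest step beyond the scatter. The position therefore takes a five-membered aromatic ring at a modest cost in binding, with compound 4 still at 25.1 nM. Nothing available explains the size of this step.

On these data alone, it remains open how an amine, a carboxylic acid or a 1,3-thiazol-2-yl would behave at this position. As far as these compounds go, whether the same change gives a similar step on the cores of compound 1 or compound 2 is also open.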